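The source may hold more compounds than are shown below. What is called first, only, known or untested is meant among the compounds shown, and "the series" means these compounds.

Measured compounds:
- compound 1, `Cc1nc(C(F)(F)F)ccc1C(=O)Nc1ccc(Cl)c(-c2nc3ccccc3[nH]2)c1`: 12 nM
- compound 2, `Cc1nc(C(F)(F)F)ccc1C(=O)Nc1ccc(Cl)c(-c2nc3ccccc3n2C)c1`: 9 nM
- compound 3, `Cc1nc(C(F)(F)F)ccc1C(=O)Nc1ccc(Cl)c(-c2nc3ccccc3s2)c1`: 70 nM

All three were tested in an assay on C3H 10T1/2 cells for inhibition of Sonic hedgehog protein (Mus musculus), read by a luciferase reporter; on this read-out higher numbers stand for weaker inhibition and lower numbers for stronger inhibition. Compound 3 stands at the highest number of the three: the step of a 5.8-fold higher number from compound 1 to compound 3 (0.77 log units; beyond the scatter) and the step of a 7.8-fold higher number from compound 2 to compound 3 (0.89 log units; beyond the scatter) both lie beyond the scatter, while the step of a 1.3-fold lower number from compound 1 to compound 2 (0.12 log units; within the scatter) does not. Compound 4, `Cc1nc(C(F)(F)F)ccc1C(=O)Nc1ccc(Cl)c(-n2cccn2)c1`, has not yet been measured. It differs from compound 3 in one place: 1H-pyrazol-1-yl in place of 1,3-benzothiazol-2-yl on an aromatic carbon.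

Within the data shown here, no measured step swaps the group at this position for one lacking the six-membered carbon ring, so nothing bears directly on the change. The two steps that end at compound 3 only show that exchanging one bicyclic group for another at this position shifts the number by a modest amount in this assay. Among the measured compounds shown here, the change to compound 4 removes more of the group than either of those steps did, so a step beyond the scatter is expected, most likely toward a higher number, though the direction rests on no measured pair. Compound 4 is therefore expected to give about 150 nM in this assay, within 30 nM to 800 nM, corresponding to an estimated step of a 2.1-fold higher number from compound 3 to compound 4 (0.33 log units; beyond the scatter).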

Compound 4, half-maximal inhibitory concentration: 450 nM
Estimate against measurement, compound 4: 3.0-fold (0.48 log units) below; the measured number falls inside the stated range.
By their numbers in this assay, from the lowest: compounds 2 and 1 (each within the scatter of the next); then compound 3; then compound 4.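

In this assay, among these compounds, 1H-pyrazol-1-yl in place of 1,3-benzothiazol-2-yl gives a 6.4-fold higher number from compound 3 to compound 4 (0.81 log units; beyond the scatter) as the first measured change at this position that leaves out the six-membered aromatic ring of carbon only, rather than exchanging one bicyclic group for another. Set against the two benzimidazole compounds, the same group gives a 50-fold higher number from compound 2 to compound 4 (1.70 log units; beyond the scatter) and a 38-fold higher number from compound 1 to compound 4 (1.57 log units; beyond the scatter), the largest steps seen so far at this place on the aromatic carbon, so a single five-membered ring does not match any of the three bicyclic groups here. Nothing measured explains why the number rises with this change.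

Going by these compounds, whether an imidazole ring joined through carbon would behave as the pyrazole does remains open. So does whether a phenyl group added to the pyrazole ring would bring the number back toward those of the bicyclic compounds.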